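The compounds below may be only part of what the source reports. "The series", "measured", "known", "first", "only" and "open" are said of these compounds alone.

Measured compounds and their values:
compound 1, `Cc1ccc(-n2c(C)cc(-c3nnc4n3CCCCC4)c2C)cc1`: 34 nM
compound 2, `CCOC(=O)c1ccc(-n2c(C)cc(-c3nnc4n3CCCCC4)c2C)cc1`: 38 nM
compound 3, `Cc1cccc(-n2cnc3cc(C(=O)N4CC(C)CC(C)C4)ccc32)c1`: 271 nM

In an assay on isolated protein for inhibition of 15-hydroxyprostaglandin dehydrogenase [NAD(+)] (Homo sapiens), read by fluorescence, with a stated time of 15 min (a higher number here means a weaker inhibitor, a lower number a stronger inhibitor), compound 3 stands highest of the three numbers. Its nearest neighbour is compound 2 at 38 nM, and the furthest is compound 1 at 34 nM; both gaps lie beyond the scatter, so compound 3 is the weakest inhibitor among the measured set. For the measured compounds named here, compounds 1 and 2 share a core of their own, and the only measured step, a 1.1-fold higher number from compound 1 to compound 2 (0.05 log units; within the scatter), concerns that core rather than the core of compound 3.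

Compound 4, `CCCCNC(=O)c1ccc2c(c1)ncn2-c1cccc(C)c1`, differs from compound 3 by butylamino in place of 3,5-dimethylpiperidin-1-yl on a carbonyl carbon. Going by the values given here, no measured step touches the amide of compound 3 or its core, so nothing measured bears directly on this change. Among the compounds with values here, the one step that exists, from compound 1 to compound 2, shows a change on an aromatic carbon that stayed within the scatter, and offers no direction here. With no guide beyond that, the expectation is that compound 4 stays close to compound 3 in this assay, with no step beyond the scatter. The step expected, a 1.1-fold higher number from compound 3 to compound 4 (0.04 log units; within the scatter), is therefore small. For compound 4 the estimated value is 300 nM, within a range from 100 nM to 900 nM.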

Compound 4, half-maximal inhibitory concentration: 1360 nM
Estimate against measurement, compound 4: 4.5-fold (0.66 log units) below; measured number above the stated range.
By their numbers in this assay, from the lowest: compounds 1 and 2 (each within the scatter of the next); then compound 3; then compound 4.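

On the carbonyl carbon, in this assay, butylamino in place of 3,5-dimethylpiperidin-1-yl gives a 5.0-fold higher number from compound 3 to compound 4 (0.70 log units; beyond the scatter), so the group held at this place does affect the number, and this change leaves a weaker inhibitor. The only earlier step, a 1.1-fold higher number from compound 1 to compound 2 (0.05 log units; within the scatter), lay on an aromatic carbon in a different core and stayed within the scatter, so this is the first single change shown that moves the number beyond it. The swap removes a ring, lowers the heavy-atom count and adds a hydrogen-bond donor all at once, and no supporting measurement separates these features or accounts for the step.

The compounds shown leave open which of these features matters, and plain piperidin-1-yl, without the two methyl groups, or butyl(methyl)amino, which keeps the chain but has no amide hydrogen, would help to pull them apart. They also leave open how a shorter chain such as ethylamino, a longer chain such as hexylamino, or a chain ending in a carboxylic acid would read at the same carbonyl carbon in this assay.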